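The source may report more compounds than this note shows. Statements on the series, on what has been measured and on what is new or still open speak of the compounds shown alone.

Working notes on the series.

Compound 1 is `CCn1c(SCC(=O)c2ccccc2)nnc1-c1ccc(OC)cc1`; in a functional assay on the whole organism (strain albino) for inhibition, with Rattus norvegicus as the target, read by paw edema, with a stated time of 4 h, at a dose of 0.28 mmol/kg by the oral route (on this read-out higher numbers stand for more inhibition at the one dose given (going by the name of the read-out) and lower numbers for less inhibition), compound 1 gives 70%. Compound 2 is `CCn1c(SCC(=O)c2ccccc2)nnc1-c1ccc(OC)c(OC)c1`; in this assay compound 2 gives 73%. Compound 3 is `CCn1c(SC/C(=N/O)c2ccccc2)nnc1-c1ccc(OC)cc1`; in this assay compound 3 gives 78%. All three values sit within the usual scatter of one another, so no order among them is read from these numbers.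

For the measured compounds named here, the one single-point change measured so far is hydrogen in place of methoxy on an aromatic carbon. Its effect is a number 3 percentage points lower from compound 2 to compound 1 (within the scatter).

Compound 4, not yet measured, is `CCn1c(SC/C(=N/O)c2ccccc2)nnc1-c1ccccc1`. Relative to compound 3 the change is hydrogen in place of methoxy on an aromatic carbon. This is the same kind of change as that from compound 2 to compound 1, not the same: in compound 3 the group sits para to a large group, whereas in compound 2 it sits ortho to a methoxy group and meta to a large group. The difference between the core of compound 3 and the core of compound 2 is not broken down here; the two differ in more than one place.

On this footing compound 4 is expected to stay close to compound 3 in this assay, the expected step being a number 5 percentage points lower from compound 3 to compound 4 (within the scatter). That expectation rests on the measured step of a number 3 percentage points lower from compound 2 to compound 1 (within the scatter), which lies within the scatter, tempered by the fact that the surroundings of the change are not identical. For compound 4 in this assay the estimate is 73%, with a likely range from 60% to 85%.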

Compound 4, a percentage reported as inhibition, in the whole organism at one dose (the size of the read-out at that dose, not a potency): 73%
Beside the measured number, compound 4's estimate shows no gap at the digits printed, and the stated range covers the measured number.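

In this assay, hydrogen in place of methoxy, here 4-methoxyphenyl to phenyl, gives a number 5 percentage points lower from compound 3 to compound 4 (within the scatter). Set beside the earlier case, the change carries from one core to the other with no difference that can be read: the same change on two cores in this assay, a number 3 percentage points lower (within the scatter) from compound 2 to compound 1 and a number 5 percentage points lower (within the scatter) from compound 3 to compound 4, 2 percentage points apart, within the scatter of two such steps. This shows only that, on these two cores, the change leaves the paw edema read-out at the one dose given within the scatter; it does not show that the methoxy group plays no part, and it cannot be extended to other cores, since the two steps are small, the surroundings of the change differ, and compound 1 keeps a methoxy group on that ring whereas compound 4 has none.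

On that aromatic ring the compounds shown carry only methoxy or hydrogen, so it remains open how an amine, a carboxylic acid or a halogen such as chlorine would behave there. Also open are a longer chain in place of the ethyl group on the shared core and how any of these compounds would compare at other doses.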